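Thiophen-3-yl in place of furan-3-yl

This account rests on a few compounds, and the source may have more. Where it says the series, first, only, none or still open, it means among the compounds named here.

compound 1 `CNc1ncnc2c1c(-c1ccccc1)cn2[C@@H]1O[C@H](CO)[C@@H](O)[C@H]1O`: > 20000 nM (a limit)
compound 2 `Nc1nc2c(c(-c3ccco3)cn2[C@@H]2O[C@H](CO)[C@@H](O)[C@H]2O)c(=O)[nH]1`: > 20000 nM (a limit)
compound 3 `Nc1nc2c(c(-c3ccoc3)cn2[C@@H]2O[C@H](CO)[C@@H](O)[C@H]2O)c(=O)[nH]1`: 17900 nM

Going by the values given here, in a functional assay on CCRF-CEM cells (Homo sapiens), read by MTT assay, with a stated time of 72 h (a higher number here means a weaker inhibitor, a lower number a stronger inhibitor), compound 3 gives 17900 nM, the only true number in this small set. The other two results are limits of the assay, not numbers: the limit of > 20000 nM in this assay, at which 2 of the 3 values shown sit.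

Compound 4 `Nc1nc2c(c(-c3ccsc3)cn2[C@@H]2O[C@H](CO)[C@@H](O)[C@H]2O)c(=O)[nH]1` differs from compound 3 in one place: thiophen-3-yl in place of furan-3-yl on an aromatic carbon.

Among the compounds with values here, the only measured step, an at least 1.1-fold lower number from compound 2 to compound 3 (0.04 log units; that floor lies within the scatter), exchanges one furan attachment for another. Within the data shown here, no measured step exchanges oxygen for sulfur, so this is weak guidance. Going by it, no change beyond the scatter is expected, and the expected step is a 1.1-fold lower number from compound 3 to compound 4 (0.05 log units; within the scatter).

For compound 4 the estimated value is 16000 nM, with an expected range of 7000 nM to 30000 nM.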

Compound 4, half-maximal inhibitory concentration: > 20000 nM
Compound 4: a limit, no number (the forecaster's own chance of this, stated with the estimate: 40%); at least 1.2-fold (0.09 log units) between middle value and limit.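

In this assay, thiophen-3-yl in place of furan-3-yl gives an at least 1.1-fold higher number from compound 3 to compound 4 (0.04 log units; that floor lies within the scatter), so exchanging the ring oxygen for sulfur at this position brings no gain in activity. Compound 4 gives a limit, not a number, as does compound 2, so the step between them cannot be read. The set now gathers at a single ceiling: the limit of > 20000 nM in this assay, at which 3 of the 4 values shown sit.

As far as these compounds go, what stays open is whether a different group at this position, such as an amine, a carboxylic acid or a longer chain, would give a clearly lower number.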